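Series at the assay limit: the step to compound 4

This account rests on a few compounds, and the source may have more. Where it says the series, first, only, none or still open, it means among the compounds named here.

In a functional assay on MCF cells (Homo sapiens) for antiproliferative activity, with a stated time of 72 h (on this read-out higher numbers stand for weaker inhibition and lower numbers for stronger inhibition), compound 1 (`OC[C@H]1O[C@@H](n2cnc3c(NCc4ccccc4Cl)ncnc32)[C@H](O)[C@@H]1O`) gives > 166000 nM as a limit and not a number. Compound 2 (`COc1cccc(CNc2ncnc3c2ncn3[C@@H]2O[C@H](CO)[C@@H](O)[C@H]2O)c1OC`) gives > 166000 nM as a limit as well. Compound 3 (`COc1cc(CNc2ncnc3c2ncn3[C@@H]2O[C@H](CO)[C@@H](O)[C@H]2O)cc(OC)c1`) gives > 166000 nM as a limit too, so it offers no number to start from. All the measured compounds stand at the limit of > 166000 nM in this assay, at which 3 of the 3 values shown sit, with nothing to rank them.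

Compound 4 (`OC[C@H]1O[C@@H](n2cnc3c(NCc4cc(O)cc(O)c4)ncnc32)[C@H](O)[C@@H]1O`) differs from compound 3 in one place (3,5-dihydroxyphenyl in place of 3,5-dimethoxyphenyl on a saturated chain carbon bound to a nitrogen on an aromatic ring). The steps a step that the two limits leave unreadable from compound 1 to compound 3 and a step that the two limits leave unreadable from compound 2 to compound 3 both change this same group and neither has a readable size. The step that the two limits leave unreadable from compound 1 to compound 2 adds no size either. Since a step that the two limits leave unreadable from compound 2 to compound 3 gives no size or direction to carry over, no step beyond the scatter is expected in this assay and compound 4 is expected to stay at the limit. The estimated step is a step that the limit leaves unreadable from compound 3 to compound 4 and no direction is expected. For compound 4 the estimate is 170000 nM with a range from 60000 nM to 400000 nM and it is expected to be reported only as a limit.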

Compound 4, half-maximal inhibitory concentration: > 166000 nM
Compound 4: no number, only a limit; the forecaster's own chance of this, stated with the estimate: 80%; the middle value lies beyond the limit too.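

In this assay compound 4 gives > 166000 nM, a limit and not a number, so the steps to it from compound 1, compound 2 and compound 3 cannot be read: the limit of > 166000 nM in this assay, at which 4 of the 4 values shown sit.

Going by these compounds, whether these four compounds differ at all in this assay, and which group in this place would give a measurable number, stays open.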